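Replacing the pyridyl amide with a Boc-pyrrolidinyl amide

The compounds below may be only part of what the source reports. "The series", "measured", "known", "first", "only" and "open" are said of these compounds alone.

Compound 1 `O=C(c1cccc(Cl)c1)N1CCC(NS(=O)(=O)c2cc(S(=O)(=O)c3ccccc3)ccc2C(F)(F)F)CC1` gives 870 nM in an assay on U2OS cells for inhibition of secreted frizzled-related protein 1 (Homo sapiens), read by a luciferase reporter, with a stated time of 18 h; on this read-out higher numbers stand for an effect only at larger amounts of compound and lower numbers for an effect already at smaller amounts.
Compound 2 `O=C(c1ccccn1)N1CCC(NS(=O)(=O)c2cc(S(=O)(=O)c3ccccc3)ccc2C(F)(F)F)CC1` gives 230 nM in this assay.
Compound 3 `CN(C)c1ccc(C(=O)N2CCC(NS(=O)(=O)c3cc(S(=O)(=O)c4ccccc4)ccc3C(F)(F)F)CC2)cn1` gives 70 nM in this assay.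

Compound 3 stands lowest of the three numbers: the step of a 3.3-fold lower number from compound 2 to compound 3 (0.52 log units; beyond the scatter) and the step of a 12-fold lower number from compound 1 to compound 3 (1.09 log units; beyond the scatter) both lie beyond the scatter, so compound 3 is the most potent of the measured set. All three measured steps, including a 3.8-fold lower number from compound 1 to compound 2 (0.58 log units; beyond the scatter), change only the aromatic group on the carbonyl carbon, and each moved the number by a modest to large amount.

Compound 4 `CC(C)(C)OC(=O)N1CC[C@H](C(=O)N2CCC(NS(=O)(=O)c3cc(S(=O)(=O)c4ccccc4)ccc3C(F)(F)F)CC2)C1` differs from compound 3 in 1-(tert-butoxycarbonyl)pyrrolidin-3-yl in place of 6-(dimethylamino)pyridin-3-yl on a carbonyl carbon. Among the measured compounds shown here, no measured step swaps the aromatic group for a non-aromatic, saturated ring of this kind, so none bears directly on the change; the three steps show only that this position is sensitive, with spreads between modest and large. A step away from the best aromatic group is therefore expected to raise the number in this assay rather than lower it, by an amount that cannot be pinned from the data. Compound 4 is accordingly expected to give about 300 nM, within a wide range from 70 nM to 1500 nM, which would mean the step of a 4.3-fold higher number from compound 3 to compound 4 (0.63 log units; beyond the scatter).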

Compound 4, half-maximal effective concentration: 150 nM
Compound 4: the middle estimate sits 2.0-fold (0.30 log units) above what was measured; the range from low to high includes it.
By their numbers in this assay, from the lowest: compound 3; then compounds 4 and 2 (each within the scatter of the next); then compound 1.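

The position on the carbonyl carbon does not depend on an aromatic ring among these compounds: 1-(tert-butoxycarbonyl)pyrrolidin-3-yl, with its five-membered non-aromatic ring, cannot be told apart from pyridin-2-yl (a 1.5-fold lower number from compound 2 to compound 4 (0.19 log units; within the scatter)) and improves clearly on 3-chlorophenyl (a 5.8-fold lower number from compound 1 to compound 4 (0.76 log units; beyond the scatter)). The 6-(dimethylamino)pyridin-3-yl group of compound 3 still keeps a modest lead over this saturated replacement (a 2.1-fold higher number from compound 3 to compound 4 (0.33 log units; beyond the scatter)), so the aromatic group gives the lowest number of the four, but a larger non-aromatic group with the same count of hydrogen-bond acceptors is tolerated here. No measurement on hand explains why these groups rank as they do.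

Because the ring and the tert-butoxycarbonyl group enter together, the compounds shown leave open which of the two accounts for the result, and whether the free pyrrolidine amine or an acetyl group on that ring nitrogen would give a similar number. Also open, from the compounds shown here alone, is how the opposite configuration at the defined stereocentre would compare with compound 4.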